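Methyl for Carbamoyl: Swapping One Ring Substituent

This account rests on a few compounds, and the source may have more. Where it says the series, first, only, none or still open, it means among the compounds named here.

Measured compounds, each value being a limit of the assay rather than a number:
- compound 1 `Cc1ccc(CCCCCC(=O)N2CCOC2=O)cc1C` in an assay on HEK293 cells for inhibition of N-acylethanolamine-hydrolyzing acid amidase (Rattus norvegicus), read by LC-MS, with a stated time of 30 min (on this read-out higher numbers stand for weaker inhibition and lower numbers for stronger inhibition), gives > 20000 nM
- compound 2 `COc1ccc(CCCCCC(=O)N2CCOC2=O)cc1` in this assay gives > 20000 nM
- compound 3 `NC(=O)c1ccc(CCCCCC(=O)N2CCOC2=O)cc1` in this assay gives > 20000 nM

Going by these compounds, compound 3 therefore stands at the edge of what this assay can report: the assay saw no inhibition up to its limit, so its true potency is unknown beyond that. The same holds for compound 1 and compound 2. For the measured compounds named here, the one step that differs in a single place, a step that the two limits leave unreadable from compound 2 to compound 3, cannot be sized, because the limit of > 20000 nM in this assay, at which 3 of the 3 values shown sit, holds for both ends of it. Compound 1 and compound 3 are further apart in structure and are not compared as a step; each simply sits at the limit.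

Compound 4 `Cc1ccc(CCCCCC(=O)N2CCOC2=O)cc1` differs from compound 3 by methyl in place of carbamoyl on an aromatic carbon. Going by the values given here, no measured step gives a readable size for any change at this position, since every value shown is a limit. The expected step is therefore a step that the limit leaves unreadable from compound 3 to compound 4, meaning no change that can be read against the scatter. Compound 4 is estimated at 30000 nM in this assay, within a range from 12000 nM to 100000 nM, most likely reported again only as a limit.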

Compound 4, half-maximal inhibitory concentration: 440 nM
Compound 4: the middle estimate sits 68-fold (1.83 log units) above what was measured; measured number below the stated range.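

The position turns out to be far from indifferent: with methyl in place of carbamoyl on the aromatic carbon para to a large group, this assay shows an at least 45-fold lower number from compound 3 to compound 4 (1.65 log units; beyond the scatter), the first readable potency in this small set. The result also depends on which small group is present, as methyl in place of methoxy gives an at least 45-fold lower number from compound 2 to compound 4 (1.65 log units; beyond the scatter), and hydrogen in place of methyl on an aromatic carbon gives an at least 45-fold lower number from compound 1 to compound 4 (1.65 log units; beyond the scatter), so a difference of a single methyl on the ring can separate a measurable inhibitor from an inactive-looking compound. Each of these steps is a minimum rather than a full size, because its starting compound has no exact value: the limit of > 20000 nM in this assay, at which 3 of the 4 values shown sit.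

Going by these compounds, it remains open whether methyl is specifically favoured at this position, or whether a chlorine atom, an ethyl group or a bare ring hydrogen would serve as well. It is also unknown whether the same preference would hold with a shorter or longer chain joining the ring to the shared core.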